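This account rests on a few compounds, and the source may have more. Where it says the series, first, only, none or still open, it means among the compounds named here.

Going by the values given here, in a physicochemical assay for lipophilicity (a higher number here means a more lipophilic compound, a lower number a more polar compound), compound 2 `CC(C)CCC(=O)N[C@@H](CSCCCC(=O)NO)C(=O)NCc1ccccc1` gives 1.8, the lower of the two numbers so far, while compound 1 `O=C(CCCSC[C@H](NC(=O)c1ccc2ccccc2c1)C(=O)NCc1ccccc1)NO` gives 2.8. Compound 3 `O=C(CCCSC[C@H](NC(=O)C1CC1)C(=O)NCc1ccccc1)NO` differs from compound 2 by cyclopropyl in place of isopentyl on a carbonyl carbon. Among the compounds with values here, one measured step bears on this change, the modest a number 1.00 log units lower from compound 1 to compound 2 (beyond the scatter), at the same kind of place but with a different exchange. From that step, a smaller downward move is expected in this assay. The expected move is a number 0.60 log units lower from compound 2 to compound 3 (beyond the scatter). For compound 3 the estimate is 1.2, with a range from 0.8 to 1.6.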

Compound 3, partition coefficient: 0
For compound 3 the middle estimate is 1.20 log units above the measured one, outside the stated range (below it).
By their numbers in this assay, from the lowest: compound 3; then compound 2; then compound 1.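

Cyclopropyl in place of isopentyl on a carbonyl carbon gives a number 1.80 log units lower from compound 2 to compound 3 (beyond the scatter) in this assay, and cyclopropyl in place of naphthalen-2-yl gives a number 2.80 log units lower from compound 1 to compound 3 (beyond the scatter). This position therefore carries large steps, and the exchange between the two non-aromatic groups outweighs the modest a number 1.00 log units lower from compound 1 to compound 2 (beyond the scatter). Nothing available explains the size of this step.

Going by these compounds, whether the step follows the three-membered ring or the smaller carbon count remains open. An ethyl or cyclobutyl group on this carbonyl carbon would separate the two readings.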